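Shortening the isobutyl chain of compound 2

The source may report more compounds than this note shows. Statements on the series, on what has been measured and on what is new or still open speak of the compounds shown alone.

Compound 1 `COc1ccc(-c2nc3ccccc3n2C(=O)c2cccc3ccccc23)cc1` gives 146 nM
Compound 2 `COc1ccc(C(=O)n2c(CC(C)C)nc3ccccc32)cc1` gives 34 nM

In a functional assay on HL-60 cells (Homo sapiens) for cytotoxicity, read by MTT assay, with a stated time of 72 h (on this read-out lower numbers stand for stronger inhibition and higher numbers for weaker inhibition), compound 2 (34 nM) holds the lower of the two numbers. Compound 1 (146 nM) stands higher, and that gap lies beyond the usual scatter of repeated measurements. Among the measured compounds shown here, no two measured compounds differ in one place only, so the data offer no measured step to serve as a guide.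

Compound 3 `COc1ccc(C(=O)n2c(C(C)C)nc3ccccc32)cc1` has not yet been measured. It carries isopropyl in place of isobutyl on an aromatic carbon. The change sits between two ring nitrogen atoms, and the chain that leaves and the one that enters are both without a ring.

The expectation rests on compound 2 (34 nM) as the closest measured neighbour. In this assay a small step is expected, probably within the scatter, and if anything toward a higher number. The estimate implies a 1.5-fold higher number from compound 2 to compound 3 (0.17 log units; within the scatter) as the expected step. For compound 3 the expected value is 50 nM (estimated range 16 nM to 160 nM).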

Compound 3, half-maximal inhibitory concentration: 630 nM
Estimate against measurement, compound 3: 13-fold (1.10 log units) below; measured number outside the range, above it.
By their numbers in this assay, from the lowest: compound 2; then compound 1; then compound 3.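

In this assay, the aromatic carbon between two ring nitrogen atoms proves highly sensitive to a small change in the chain: isopropyl in place of isobutyl gives a 19-fold higher number from compound 2 to compound 3 (1.27 log units; beyond the scatter), a large step well beyond the scatter. Both chains are without a ring, carry no hydrogen-bond donors or acceptors and have no net charge, so of the features counted here only the drop from 4 heavy atoms to 3 separates them, and this one change is enough to move the number that far. No measurement at hand accounts for the size of this step.

The compounds shown leave open how the number responds to a longer chain at this place, such as n-pentyl or isopentyl, and whether the straight n-propyl chain behaves like isobutyl or like isopropyl. They also leave open whether a small ring such as cyclopropyl or a chain ending in an amine would be accepted there, and whether the same step would appear with a naphthalene carbonyl group in place of the methoxy-substituted benzoyl group.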